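The compounds below may be only part of what the source reports. "The series", "measured", "known", "first", "only" and "open" are said of these compounds alone.

For the measured compounds named here, the three compounds measured so far share one core and differ only in the group on one aromatic carbon of the five-membered ring with three nitrogen. Compound 3 `CC(C)(C)c1cn(C[C@H](O)[C@H]2OC(=O)C(OCc3ccccc3)=C2OCc2ccccc2)nn1` is one of them; in a functional assay on CFPAC-1 cells (Homo sapiens) for antiproliferative activity, read by MTT assay, with a stated time of 72 h (a higher number here means a weaker inhibitor, a lower number a stronger inhibitor), compound 3 gives 54900 nM, the highest of the three numbers, though all three lie within the scatter of one another. Compound 1 `O=C1O[C@H]([C@@H](O)Cn2cc(-c3cccc(O)c3)nn2)C(OCc2ccccc2)=C1OCc1ccccc1` gives 54100 nM in this assay, and compound 2 `CCCCCCCCCCc1cn(C[C@H](O)[C@H]2OC(=O)C(OCc3ccccc3)=C2OCc2ccccc2)nn1` gives 40300 nM. The steps among them are small: a 1.3-fold lower number from compound 1 to compound 2 (0.13 log units; within the scatter), a 1.0-fold higher number from compound 1 to compound 3 (0.01 log units; within the scatter) and a 1.4-fold higher number from compound 2 to compound 3 (0.13 log units; within the scatter). Compound 4 `O=C1O[C@H]([C@@H](O)Cn2cc(CNS(=O)(=O)c3ccc(Cl)cc3)nn2)C(OCc2ccccc2)=C1OCc1ccccc1` has not been measured; it differs from compound 3 in that ((((4-chlorophenyl)sulfonyl)amino)methyl in place of tert-butyl on an aromatic carbon). The three measured steps all bear on this same position, each exchanging one group there for another, and none of them moved the number beyond the scatter. No step beyond the scatter is therefore expected in this assay for this change either. Compound 4 is thus expected to give about 50000 nM in this assay, with a range from 20000 nM to 120000 nM, which corresponds to the step of a 1.1-fold lower number from compound 3 to compound 4 (0.04 log units; within the scatter).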

Compound 4, half-maximal inhibitory concentration: 38900 nM
The estimate for compound 4 lay 1.3-fold (0.11 log units) above the measured number; low and high end bracket the measured number.
By their numbers in this assay, from the lowest: compounds 4, 2, 1 and 3 (each within the scatter of the next).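

For the compounds shown here, compound 4 carries the only group of the four with sulfur and chlorine, yet in this assay the exchange gives a 1.4-fold lower number from compound 3 to compound 4 (0.15 log units; within the scatter), and the comparisons with the other two give a 1.0-fold lower number from compound 2 to compound 4 (0.02 log units; within the scatter) and a 1.4-fold lower number from compound 1 to compound 4 (0.14 log units; within the scatter). This aromatic carbon has now held a decyl chain, tert-butyl, 3-hydroxyphenyl and (((4-chlorophenyl)sulfonyl)amino)methyl, and no step among these four compounds lies beyond the scatter, so the sulfonyl-bearing group adds a further kind of substituent to that flat picture. Nothing available here explains why the number responds so little to these exchanges.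

As far as these compounds go, whether an amine or a carboxylic acid on this carbon would move the number beyond the scatter remains open. So does the contribution of the shared core, including its two benzyl ethers, since all four compounds carry it unchanged.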